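A few compounds are considered here, and "the series" means these few. Any claim that something is new, unique, unknown or untested is made for them only; others in the source may bear on it.

Working notes on the porcupine series. Compound 2 `CCOc1ccc(NC(=O)CSc2nc3c(c(=O)n2-c2ccccc2)SCC3)cc1` gives 1000 nM in an assay on L cells for inhibition of Protein-serine O-palmitoleoyltransferase porcupine (Mus musculus), read by reporter gene assay, with a stated time of 24 h (a lower number here means that less compound is needed, a higher number that more compound is needed for the effect), and is the highest of the three numbers measured; compound 1 `O=C(CSc1nc2c(c(=O)n1-c1ccccc1)SCC2)Nc1nc2ccc(Cl)cc2s1` gives 40 nM and compound 3 `COc1ccc(-n2nc(C(=O)NCC(=O)Nc3nc4ccc(Cl)cc4s3)c3ccccc3c2=O)cc1` gives 15 nM in this assay. Among the compounds with values here, the one step at the amide-type nitrogen, a 25-fold higher number from compound 1 to compound 2 (1.40 log units; beyond the scatter), shows that the group on this nitrogen shifts the number far beyond the scatter. Compound 4 `O=C(CSc1nc2c(c(=O)n1-c1ccccc1)SCC2)Nc1ccc(-c2ccccc2)cc1` carries phenyl in place of ethoxy on an aromatic carbon. Within the data shown here, no measured step exchanges a substituent on that ring itself, so the step from compound 1 to compound 2 is only indirect guidance; a moderate move below compound 2 is expected, a 2.5-fold lower number from compound 2 to compound 4 (0.40 log units; beyond the scatter). For compound 4 the estimate in this assay is 400 nM, range 100 nM to 2000 nM.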

Compound 4, half-maximal effective concentration: 0.75 nM
Beside the measured number, compound 4's estimate is 530-fold (2.73 log units) above it, outside the stated range (below it).
By their numbers in this assay, from the lowest: compound 4; then compound 3; then compound 1; then compound 2.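

Exchanging ethoxy for phenyl at this position, on an aromatic carbon para to a large group, gives a 1300-fold lower number from compound 2 to compound 4 (3.12 log units; beyond the scatter) in this assay. This single change on the ring is larger than the exchange of the whole group on the amide-type nitrogen, a 25-fold higher number from compound 1 to compound 2 (1.40 log units; beyond the scatter), so the high number of compound 2 does not follow from an aryl ring on that nitrogen as such. Nothing available explains the size of this step.

Open, going by these compounds, is whether a smaller group such as methyl, or an amine or a carboxylic acid, at this position keeps the number low. Also open, on these data alone, is whether a second aromatic ring is needed at all.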